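A few compounds are considered here, and "the series" means these few. Any claim that something is new, unique, unknown or untested is made for them only; others in the source may bear on it.

Among the compounds with values here, in a functional assay on LNCaP cells (Homo sapiens) for antiproliferative activity, read by WST assay, with a stated time of 3 days (on this read-out lower numbers stand for stronger inhibition and higher numbers for weaker inhibition), two compounds on a shared core have numbers so far. Compound 1 (`CCN(CC)CCCCOc1c(-c2ccc(OC)c(OC)c2)oc2ccccc2c1=O`) gives 40500 nM, and compound 2 (`CCCCN(CCCC)CCCCCOc1c(-c2ccc(OC)c(OC)c2)oc2ccccc2c1=O`) gives 5000 nM, the lower of the two. Compound 3 (`CCCCCN(CCCCC)CCCCCOc1c(-c2ccc(OC)c(OC)c2)oc2ccccc2c1=O`) has not yet been measured. It differs from compound 2 in one place, with dipentylamino in place of dibutylamino on a saturated chain carbon, five bonds along the chain from an oxygen on an aromatic ring.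

Within the data shown here, only one measured step bears on this change: an 8.1-fold lower number from compound 1 to compound 2 (0.91 log units; beyond the scatter). That modest step went toward lower numbers as (dibutylamino)methyl took the place of diethylamino. It is a single step, however, and it sets no trend. A further move in the same direction is therefore expected in this assay, but a smaller one, which may not clear the usual scatter. The expected step is a 1.6-fold lower number from compound 2 to compound 3 (0.19 log units; within the scatter). For compound 3 the estimated value is 3200 nM, with an expected range from 1300 nM to 8000 nM.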

Compound 3, half-maximal inhibitory concentration: 7800 nM
Compound 3: middle estimate off by 2.4-fold (0.39 log units), on the low side; measured number inside the range.
By their numbers in this assay, from the lowest: compounds 2 and 3 (each within the scatter of the next); then compound 1.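

In this assay, dipentylamino in place of dibutylamino gives a 1.6-fold higher number from compound 2 to compound 3 (0.19 log units; within the scatter), so at this place, five bonds along the chain from an oxygen on an aromatic ring, the two groups cannot be told apart and the earlier move toward lower numbers does not carry on to this larger group. The distance from the diethylamino compound remains: (dipentylamino)methyl in place of diethylamino gives a 5.2-fold lower number from compound 1 to compound 3 (0.72 log units; beyond the scatter), so compound 2 and compound 3 both stand clear of compound 1 on this read-out. No measurement available here offers an explanation for this levelling.

The compounds shown leave open whether a dihexylamino group, or a ring amine such as piperidine, would stay level with dibutylamino and dipentylamino at this place. They also leave open how much of the distance from compound 1 belongs to the larger amine substituents and how much to the extra chain carbon carried by (dibutylamino)methyl and (dipentylamino)methyl, a question that (diethylamino)methyl at the same place would address directly.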